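The source may report more compounds than this note shows. Statements on the series, on what has been measured and on what is new or still open speak of the compounds shown alone.

For the measured compounds named here, compound 2 `CC(C)c1ccc(/C=N/NC(=O)CSc2nnnn2C)cc1` stands at the lower of the two numbers so far in an ADME assay on NIH3T3 cells (Mus musculus) for cytotoxicity, read by XTT assay, with a stated time of 24 h (on this read-out lower numbers stand for stronger inhibition and higher numbers for weaker inhibition), where compound 2 gives 1200000 nM, and compound 1 `Cc1ccc(/C=N/NC(=O)CSc2nnnn2C)cc1` gives 3160000 nM. Going by the values given here, the only measured step is a 2.6-fold lower number from compound 1 to compound 2 (0.42 log units; beyond the scatter), the change being isopropyl in place of methyl on an aromatic carbon. Compound 3 `COc1ccc(/C=N/NC(=O)CSc2nnnn2C)cc1` has not yet been measured. The change from compound 2 to compound 3 is methoxy in place of isopropyl on an aromatic carbon. Among the compounds with values here, no measured step carries this exact change; the step from compound 1 to compound 2 bears on it only in that it shows what the isopropyl itself was worth, and that step was modest. On these data alone, since the isopropyl now leaves again, and the methoxy is untested here, the expectation is that the number moves back toward that of compound 1 rather than falling further. Compound 3 is therefore expected to give about 2500000 nM in this assay, with a range from 800000 nM to 7000000 nM, which means an expected step of a 2.1-fold higher number from compound 2 to compound 3 (0.32 log units; beyond the scatter).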

Compound 3, half-maximal inhibitory concentration: > 10000000 nM
Compound 3: only a limit was reported; the forecaster's own chance of this, stated with the estimate: 10%; at least 4.0-fold (0.60 log units) between middle value and limit.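

The value of compound 3 in this assay is a limit and not a number: the limit of > 10000000 nM in this assay, at which 1 of the 3 values shown sits. Even so, the position on an aromatic carbon, para to a large group, tolerates less exchange than the earlier pair suggested, since methoxy in place of isopropyl gives an at least 8.3-fold higher number from compound 2 to compound 3 (0.92 log units; beyond the scatter), and methoxy in place of methyl gives an at least 3.1-fold higher number from compound 1 to compound 3 (0.50 log units; beyond the scatter). Both steps run in the same direction, which places compound 3 on the side of weaker inhibition relative to compound 1 and compound 2, the two compounds with only carbon in this group, and shows that the identity of the group here matters in this assay beyond the change from methyl to isopropyl.

The compounds shown leave open whether this shift belongs to methoxy alone or to oxygen-bearing groups at this place more widely, a question that a hydroxy or an ethoxy group would address. They also leave open whether a tert-butyl group would continue the lower number seen with isopropyl, and how an amine would behave at the same place.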